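The source may report more compounds than this note shows. Statements on the series, on what has been measured and on what is new or still open speak of the compounds shown alone.

In a functional assay on NCI-H460 cells (Homo sapiens) for cytotoxicity, read by MTT assay (a higher number here means a weaker inhibitor, a lower number a stronger inhibitor), compound 1 `Cc1ccccc1Nc1nc(C)c(C(=O)/C=C/c2ccc(Cl)cc2)s1` reaches only the limit > 25000 nM.
In this assay compound 2 `Cc1ccc(Nc2nc(C)c(C(=O)/C=C/c3ccc(Cl)cc3)s2)cc1` reaches only the limit > 25000 nM.
In this assay compound 3 `COc1cc(/C=C/C(=O)c2sc(Nc3ccc(C)cc3)nc2C)cc(OC)c1OC` reaches only the limit > 25000 nM.

All three measured compounds sit at the limit of > 25000 nM in this assay, at which 3 of the 3 values shown sit, so none of them shows a readable number. Compound 2 and compound 1 differ by one change, (2-methylphenyl in place of 4-methylphenyl on a nitrogen on an aromatic ring); the step that the two limits leave unreadable from compound 2 to compound 1 cannot be sized because both values rest on (the limit of > 25000 nM in this assay, at which 3 of the 3 values shown sit). How the core of compound 2 differs from the core of compound 3 is not broken down here.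

Compound 4 `COc1cc(/C=C/C(=O)c2sc(Nc3ccccc3C)nc2C)cc(OC)c1OC` is the unmeasured compound; it differs from compound 3 by 2-methylphenyl in place of 4-methylphenyl on a nitrogen on an aromatic ring, the same change as that from compound 2 to compound 1, at the same kind of place. The step that the limit leaves unreadable from compound 3 to compound 4 is expected to be flat, since the earlier step that the two limits leave unreadable from compound 2 to compound 1 gave no readable size and compound 3 itself sits at the limit of > 25000 nM in this assay, at which 3 of the 3 values shown sit. Compound 4 is therefore estimated at 40000 nM, between 12000 nM and 150000 nM, most likely reported only as a limit.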

Compound 4, half-maximal inhibitory concentration: 6320 nM
Beside the measured number, compound 4's estimate is 6.3-fold (0.80 log units) above it; the measured number lies below the stated range.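

On the core of compound 3, putting 2-methylphenyl in place of 4-methylphenyl gives an at least 3.9-fold lower number from compound 3 to compound 4 (0.59 log units; beyond the scatter), so compound 4 is the stronger of the two in this assay. The matching step on the core of compound 2 cannot be read, because both of its values are limits, as are most values in this set: the limit of > 25000 nM in this assay, at which 3 of the 4 values shown sit. This one readable pair therefore shows that the change can matter on one core, but it does not show that the change carries over from one core to another.

Going by these compounds, it remains open how a plain phenyl or a pyridine ring on the same nitrogen would read on the core of compound 4. On these data alone, whether the gain would also appear in other cell lines also remains open.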